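Chain extension on the hydrazone carbon of a nitroaryl thiazole

The source may report more compounds than this note shows. Statements on the series, on what has been measured and on what is new or still open speak of the compounds shown alone.

Measured compounds:
compound 1, `CCC/C(C)=N\Nc1nc(-c2cccc([N+](=O)[O-])c2)cs1`, 1200000 nM
compound 2, `CCCCC/C(CC)=N\Nc1nc(-c2cccc([N+](=O)[O-])c2)cs1`, 1170000 nM
compound 3, `CCCC/C(CC)=N\Nc1nc(-c2cccc([N+](=O)[O-])c2)cs1`, 1260000 nM

In a functional assay, with a stated time of 30 min (a higher number here means a weaker inhibitor, a lower number a stronger inhibitor), compound 1 gives 1200000 nM, the second highest of the three numbers; compound 2 is its nearest neighbour and compound 3 its furthest, and both sit within the scatter of compound 1, so no order among the three can be read from this assay. Among the compounds with values here, the one single-point comparison available is the shortening of the chain, a 1.1-fold higher number from compound 2 to compound 3 (0.03 log units; within the scatter); it shows that removing a chain carbon at this distance from the carbon doubly bonded to nitrogen leaves this assay unmoved.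

Compound 4, `CCCCCC/C(C)=N\Nc1nc(-c2cccc([N+](=O)[O-])c2)cs1`, is not yet measured. It differs from compound 1 by propyl in place of hydrogen on a saturated chain carbon, three bonds along the chain from a carbon with a double bond to nitrogen. The chain of compound 4 is thus the chain of compound 1 lengthened by three carbons. Within the data shown here, the only relevant precedent, the step from compound 2 to compound 3 in this assay, was within the scatter, and compound 2 and compound 3, which carry chains of differing length, give values that do not differ beyond it. The expected step of no change at the digits printed from compound 1 to compound 4 (within the scatter) is therefore none beyond the scatter. Compound 4 is estimated at 1200000 nM in this assay, with a range from 600000 nM to 2400000 nM.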

Compound 4, half-maximal inhibitory concentration: 1150000 nM
Beside the measured number, compound 4's estimate is 1.0-fold (0.02 log units) above it; low and high end bracket the measured number.
By their numbers in this assay, from the lowest: compounds 4, 2, 1 and 3 (each within the scatter of the next).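

In this assay, propyl in place of hydrogen on a saturated chain carbon, three bonds along the chain from a carbon with a double bond to nitrogen, gives a 1.0-fold lower number from compound 1 to compound 4 (0.02 log units; within the scatter), so a change at this position, and one that adds a whole propyl rather than the single methyl of the earlier comparison, also leaves the number unmoved. Read with a 1.1-fold higher number from compound 2 to compound 3 (0.03 log units; within the scatter), the two steps show no dependence on chain length at either place along the chain, and none of the compounds shown goes against this, though the claim reaches only these four compounds and says nothing of what the chain contributes to the measured number in the first place. No independent data bear on why the number stays where it does.

The compounds shown leave open whether anything other than a plain saturated chain can shift the number at this position, such as an amine or a carboxylic acid at the chain end, a phenyl ring, or a chain longer than hexyl. They also leave open whether changes to the shared core, for instance an amine in place of the nitro group, would do more than any change to the chain has done.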